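Shortening a propyl chain in a Rho kinase inhibitor series

The source may hold more compounds than are shown below. What is called first, only, known or untested is meant among the compounds shown, and "the series" means these compounds.

Three compounds sharing the same core were measured in an assay for inhibition of Rho-associated protein kinase 1 (Homo sapiens), read by TR-FRET, with stated times of 5 min and 2 h; a higher number here means a weaker inhibitor, a lower number a stronger inhibitor. Compound 1 `Cc1n[nH]cc1-c1cc2c(s1)C(=O)NC(C)(C)N2C` gives 54 nM. Compound 2 `CCCC1(C)NC(=O)c2sc(-c3ccncc3)cc2N1` gives 33 nM, the lowest of the three numbers, though its gap to compound 1 lies within the scatter; compound 3 `Cc1n[nH]cc1-c1cc2c(s1)C(=O)N[C@]1(CC[C@](O)(C3CCCCC3)CC1)N2` gives 2900 nM, far weaker than either. Compound 4 `CCC1(C)NC(=O)c2sc(-c3ccncc3)cc2N1` has not yet been measured. It differs from compound 2 by a single change: hydrogen in place of methyl on a saturated chain carbon, two bonds along the chain from a saturated ring carbon, that is, propyl to ethyl. Among the compounds with values here, no step between measured compounds isolates this kind of chain shortening, so there is nothing here to anchor a direction. Compound 4 is therefore expected to stay close to compound 2, with a step of a 1.4-fold higher number from compound 2 to compound 4 (0.13 log units; within the scatter) that is expected to fall within the scatter, and an estimated value of 45 nM (range 18 nM to 110 nM).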

Compound 4, half-maximal inhibitory concentration: 36 nM
The estimate for compound 4 lay 1.3-fold (0.10 log units) above the measured number; low and high end bracket the measured number.
By their numbers in this assay, from the lowest: compounds 2, 4 and 1 (each within the scatter of the next); then compound 3.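

In this assay, within the data shown here, the change from propyl to ethyl on a saturated chain carbon, two bonds along the chain from a saturated ring carbon, gives a 1.1-fold higher number from compound 2 to compound 4 (0.04 log units; within the scatter) and is the first step here to isolate a chain shortening. Within this pair, removing that methyl leaves no change that can be told from the scatter. No measurement shown gives a reason for this outcome.

As far as these compounds go, whether a longer chain such as butyl, or an amine at the chain end, would be tolerated as well remains open.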